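Swapping a Furan for a Chlorophenyl on a Thiazole Acid

The source may hold more compounds than are shown below. What is called first, only, known or untested is meant among the compounds shown, and "the series" means these compounds.

Measured compounds:
- compound 1, `O=C(O)Cc1sc(COc2ccc(Cl)cc2)nc1-c1ccc(Cl)cc1`, 32 nM
- compound 2, `O=C(O)Cc1sc(C(c2ccc(F)cc2)c2ccc(F)cc2)nc1-c1ccoc1`, 14 nM
- compound 3, `O=C(O)Cc1sc(C2COc3ccccc3O2)nc1-c1ccc(Cl)cc1`, 500 nM

These three compounds were tested in an in vitro assay on HEK385-7 cells for displacement of a labelled ligand from prostaglandin D2 receptor 2 (Homo sapiens); on this read-out lower numbers stand for stronger inhibition and higher numbers for weaker inhibition. Compound 2 has the lowest number of the three, so it is the strongest binder in this set. Its nearest neighbour is compound 1, whose value lies beyond the usual scatter, and compound 3 sits far higher still.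

Compound 4, `O=C(O)Cc1sc(C(c2ccc(F)cc2)c2ccc(F)cc2)nc1-c1ccc(Cl)cc1`, has not yet been measured. It keeps everything of compound 2 except one group: 4-chlorophenyl in place of furan-3-yl on an aromatic carbon. The large group on the other side of the shared core is unchanged. Within the data shown here, no measured pair shows this exact swap, so the data give no direct guide to its size. Compound 1 and compound 3 both carry the 4-chlorophenyl group and differ widely from each other, which shows that the other group matters at least as much.

The step from compound 2 to compound 4 is expected to be small, likely within the scatter, perhaps a modest rise: a 1.4-fold higher number from compound 2 to compound 4 (0.15 log units; within the scatter). Compound 4 is therefore estimated at 20 nM, with a plausible range from 6 nM to 70 nM.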

Compound 4, half-maximal inhibitory concentration: 9.7 nM
Estimate against measurement, compound 4: 2.1-fold (0.31 log units) above, and the stated range covers the measured number.
By their numbers in this assay, from the lowest: compounds 4 and 2 (each within the scatter of the next); then compound 1; then compound 3.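

In this assay, the swap gives a 1.4-fold lower number from compound 2 to compound 4 (0.16 log units; within the scatter), so with the large group on the shared core held fixed, furan-3-yl and 4-chlorophenyl cannot be told apart at this position next to the ring nitrogen. The change replaces a five-membered ring with a larger six-membered one and removes the hydrogen-bond acceptor of furan-3-yl, yet the number stays within the scatter, so in this pair that acceptor is not required for a low number. Nothing measured here explains why the two groups give such close numbers.

Still open, going by these compounds, is whether a much smaller group, such as methyl, or a pyridine ring would be accepted at this position. Also open, on these data alone, is whether furan-3-yl would match 4-chlorophenyl on the cores of compound 1 and compound 3.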